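The compounds below may be only part of what the source reports. "The series", "measured", "known", "first", "only" and "open" are said of these compounds alone.

Measured compounds:
- compound 1, `Cc1c(C(=O)Nc2ccc(Oc3ccnc4[nH]ccc34)c(F)c2)nnn1-c1ccccc1F`: 3240 nM
- compound 2, `Cc1c(C(=O)Nc2ccc(Oc3ccnc4[nH]ccc34)c(F)c2)nnn1-c1ccc(F)cc1`: 4350 nM

Both were tested in a functional assay on PC-3 cells (Homo sapiens) for cytotoxicity, read by MTT assay, with a stated time of 72 h; a higher number here means a weaker inhibitor, a lower number a stronger inhibitor. Compound 2 gives the higher of the two numbers, but its gap to compound 1 lies within the scatter, so the two cannot be told apart on these data. Compound 3, `Cc1c(C(=O)Nc2ccc(Oc3ccnc4[nH]ccc34)c(F)c2)nnn1-c1ccc(F)c(F)c1`, has not yet been measured; it differs from compound 2 by fluoro in place of hydrogen on an aromatic carbon, so that the 4-fluorophenyl becomes 3,4-difluorophenyl. Among the compounds with values here, the only measured step that touches this part of the molecule is a 1.3-fold higher number from compound 1 to compound 2 (0.13 log units; within the scatter), where moving the single fluoro from one position of the phenyl to another changed little. Since a second fluoro on the same ring is a small addition and the nearest comparison stayed flat, compound 3 is expected to land close to compound 2, with a step of a 1.1-fold lower number from compound 2 to compound 3 (0.04 log units; within the scatter) that stays within the scatter. Compound 3 is therefore estimated at 4000 nM, between 1800 nM and 9000 nM.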

Compound 3, half-maximal inhibitory concentration: 6540 nM
For compound 3 the middle estimate is 1.6-fold (0.21 log units) below the measured one; the range from low to high includes it.
By their numbers in this assay, from the lowest: compounds 1, 2 and 3 (each within the scatter of the next, the first and the last beyond it).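

In this assay, putting a second fluoro on the 4-fluorophenyl, on the aromatic carbon ortho to a fluoro group, gives a 1.5-fold higher number from compound 2 to compound 3 (0.18 log units; within the scatter), so this single addition does not separate the two compounds. Within the data shown here, the comparison with the 2-fluorophenyl is different: a 2.0-fold higher number from compound 1 to compound 3 (0.31 log units; beyond the scatter) is the first step in this small set to pass the scatter, though only modestly, and it shows that the phenyl on the aromatic nitrogen can shift the number in the direction of a weaker inhibitor. Nothing available explains this shift.

From the compounds shown here alone, all three compounds carry only fluoro on this phenyl, so it remains open how an unsubstituted phenyl, a methoxy group or an amine at these positions would read. Going by these compounds, it is also open whether any change on this ring can bring the number down rather than up.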